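Chloro for Fluoro Repeated, Read by Paw Edema

The source may hold more compounds than are shown below. What is called first, only, known or untested is meant among the compounds shown, and "the series" means these compounds.

Of the compounds shown here, three have so far been measured in a functional assay on the whole organism (strain Wistar) for inhibition, with Rattus norvegicus as the target, read by paw edema, with a stated time of 30 min, at a dose of 50 mg/kg by the oral route; a higher number here means more inhibition at the dose given (going by the name of the read-out), a lower number less inhibition. Compound 1 `Clc1ccc(C2=NNC(c3cn(-c4ccccc4)nc3-c3ccc(Cl)c(Cl)c3)C2)cc1` gives 33%, compound 2 `Fc1ccc(C2=NNC(c3cn(-c4ccccc4)nc3-c3ccc(Cl)c(Cl)c3)C2)cc1` gives 45.7%, and compound 3 `O=[N+]([O-])c1ccc(N2N=C(c3ccc(F)cc3)CC2c2cn(-c3ccccc3)nc2-c2ccc(Cl)c(Cl)c2)cc1` gives 45.7%, so that compound 2 and compound 3 stand level at the digits reported and together hold the highest numbers of the three.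

Compound 1 differs from compound 2 by chloro in place of fluoro on an aromatic carbon, and this change gave a number 12.7 percentage points lower from compound 2 to compound 1 (beyond the scatter). Compound 3 differs from compound 2 by 4-nitrophenyl in place of hydrogen on an amine nitrogen in a ring, with no change at the digits printed from compound 2 to compound 3 (within the scatter); this is how the core of compound 3 differs from the core of compound 2.

Compound 4 `O=[N+]([O-])c1ccc(N2N=C(c3ccc(Cl)cc3)CC2c2cn(-c3ccccc3)nc2-c2ccc(Cl)c(Cl)c2)cc1` has not yet been measured in this assay. It differs from compound 3 by chloro in place of fluoro on an aromatic carbon, the same change, at the same place, that turns compound 2 into compound 1. Because that earlier change gave a number 12.7 percentage points lower from compound 2 to compound 1 (beyond the scatter), a step of similar size is expected here, namely a number 11.7 percentage points lower from compound 3 to compound 4 (beyond the scatter). Compound 4 is accordingly estimated at 34%, with a likely range from 22% to 47%. This rests on a single earlier pair, and on nothing more.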

Compound 4, a percentage reported as inhibition, in the whole organism at one dose (the size of the read-out at that dose, not a potency): 48.9%
For compound 4 the middle estimate is 14.9 percentage points below the measured one, and the stated range ends below it.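

In this assay, chloro in place of fluoro on an aromatic carbon gave a number 3.2 percentage points higher from compound 3 to compound 4 (within the scatter), so the drop seen on the core without the 4-nitrophenyl group did not carry over to the core that bears it: the same change on two cores in this assay, a number 12.7 percentage points lower (beyond the scatter) from compound 2 to compound 1 and a number 3.2 percentage points higher (within the scatter) from compound 3 to compound 4, 15.9 percentage points apart, beyond the scatter of two such steps Seen from the other side of the same four compounds, 4-nitrophenyl in place of hydrogen on an amine nitrogen in a ring gave a number 15.9 percentage points higher from compound 1 to compound 4 (beyond the scatter), so the outcome of that change also differed with the halogen present: the same change on two cores in this assay, no change at the digits printed (within the scatter) from compound 2 to compound 3 and a number 15.9 percentage points higher (beyond the scatter) from compound 1 to compound 4, 15.9 percentage points apart, beyond the scatter of two such steps Both comparisons rest on the same four values and describe a single mismatch, so they show that a step taken from one of these cores cannot be relied on for the other, but they do not show why the steps differ or how either change would behave on a further core.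

As far as these compounds go, it remains open how a bromo, methyl or methoxy group would read at the place of the halogen. From the compounds shown here alone, it is equally open whether an acetyl group or an unsubstituted phenyl on the amine nitrogen in a ring would follow compound 3 and compound 4.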